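This account rests on a few compounds, and the source may have more. Where it says the series, first, only, none or still open, it means among the compounds named here.

Measured compounds:
- compound 1, `Cc1c(C(=O)N/N=C\c2cccc(F)c2O)oc2cccc(O)c12`, in a functional assay on PC-3 cells (Homo sapiens) for inhibition; a higher number here means a weaker inhibitor, a lower number a stronger inhibitor: 12700 nM
- compound 2, `Cc1c(C(=O)N/N=C\c2ccccn2)oc2cccc(O)c12`, in this assay: >= 40000 nM, which is a limit of the assay and not a number

Among the compounds with values here, compound 1 holds the only numerical value shown; the other entry is a limit. The step from compound 1 to compound 2 shows an at least 3.1-fold higher number from compound 1 to compound 2 (0.49 log units; beyond the scatter), and it runs into a limit: the limit of >= 40000 nM in this assay, at which 1 of the 2 values shown sits.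

Compound 3, `Cc1c(C(=O)N/N=C\c2ccc(F)cc2)oc2cccc(O)c12`, is not yet measured. It differs from compound 1 as follows: 4-fluorophenyl in place of 3-fluoro-2-hydroxyphenyl on a carbon with a double bond to nitrogen. Within the data shown here, the one measured step bears on this change only loosely, since it swaps the 3-fluoro-2-hydroxyphenyl for pyridin-2-yl rather than for 4-fluorophenyl, but it shows that replacing this group can weaken inhibition beyond the scatter. Among the measured compounds shown here, a step toward a higher number is therefore expected, though smaller than the one to compound 2. Compound 3 is expected to give 25000 nM, in the range 8000 nM to 60000 nM, an estimated step of a 2.0-fold higher number from compound 1 to compound 3 (0.29 log units; within the scatter).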

Compound 3, half-maximal inhibitory concentration: >= 40000 nM
Compound 3 was reported as a limit; the forecaster's own chance of this, stated with the estimate: 35%; middle value at least 1.6-fold (0.20 log units) away from the limit.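

Placing 4-fluorophenyl in place of 3-fluoro-2-hydroxyphenyl on a carbon with a double bond to nitrogen gives an at least 3.1-fold higher number from compound 1 to compound 3 (0.49 log units; beyond the scatter), so a second, carbon-only aromatic replacement also weakens inhibition beyond the scatter. Compound 3, like compound 2, ends at a limit of the assay and not a number: the limit of >= 40000 nM in this assay, at which 2 of the 3 values shown sit. A fluorinated phenyl without the hydroxy group therefore gives no numerical value in this assay, and the step from compound 2 to compound 3 cannot be read, as both entries are limits.

Still open, as far as these compounds go, is whether the hydroxy group or the placement of the fluorine carries the difference, since compound 3 changes both at once. A 2-hydroxyphenyl without fluorine, or a 2-methoxyphenyl or 2-aminophenyl group at this place, would separate these two changes.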